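The source may hold more compounds than are shown below. What is called first, only, known or untested is meant among the compounds shown, and "the series" means these compounds.

In a functional assay on HCT-116 cells (Homo sapiens) for antiproliferative activity, read by CCK-8 assay, with a stated time of 72 h (on this read-out lower numbers stand for stronger inhibition and higher numbers for weaker inhibition), compound 1 `COc1ccc(SCc2ccc(C(=O)Nc3ccccc3N)cc2)cc1` gives 1640 nM. Among the compounds with values here, only one other compound offers a number for comparison: compound 3 `COc1ccc(SCc2ccc(C(=O)Nc3ccccc3N)cc2)cc1OC` gives 2000 nM, so compound 1 stands level with it within the scatter. Compound 2 `Nc1ccccc1NC(=O)/C=C/c1ccc(CSCCc2ccccc2)cc1` cannot help, since its entry for this read-out is "not determined" (no result reported).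

The next compound to consider is compound 4 `Nc1ccccc1NC(=O)c1ccc(CSc2ccc(F)cc2)cc1`, which keeps the core of compound 1 and alters a single group: fluoro in place of methoxy on an aromatic carbon. In plain words, this is fluoro in place of methoxy on an aromatic carbon, so 4-methoxyphenyl becomes 4-fluorophenyl.

Within the data shown here, only one measured step bears on this change, and it is an imperfect guide. It places methoxy in place of hydrogen on an aromatic carbon and gives a 1.2-fold higher number from compound 1 to compound 3 (0.09 log units; within the scatter). Among the measured compounds shown here, that step shows one substitution on an aromatic carbon that stays within the scatter, but no measured compound carries fluoro, so the data give no basis for choosing a direction. No step beyond the scatter is therefore expected in this assay, and the expected result is a 1.0-fold lower number from compound 1 to compound 4 (0.01 log units; within the scatter). With so little evidence, the range must stay wide. For compound 4 the estimated value is 1600 nM, with an expected range from 600 nM to 4500 nM.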

Compound 4, half-maximal inhibitory concentration: 4010 nM
Estimate against measurement, compound 4: 2.5-fold (0.40 log units) below; the range from low to high includes it.
By their numbers in this assay, from the lowest: compounds 1, 3 and 4 (each within the scatter of the next, the first and the last beyond it).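

In this assay the change from 4-methoxyphenyl to 4-fluorophenyl gives a 2.4-fold higher number from compound 1 to compound 4 (0.39 log units; beyond the scatter) and so, unlike the earlier step, lies beyond the scatter, although only modestly. That earlier step, a 1.2-fold higher number from compound 1 to compound 3 (0.09 log units; within the scatter) and within the scatter, added a further methoxy to the same aromatic ring and left open whether the substituents on this ring matter at all in this cell assay; the new pair shows that replacing the methoxy para to a large group can shift the number, and that here the shift is toward weaker inhibition. Nothing in the data shown explains why this swap of methoxy for fluoro has this effect.

A single pair cannot separate what fluoro brings from what is lost with the methoxy, so the result does not show whether the methoxy helps or the fluoro hurts. Plain hydrogen at this place would help to tell these apart, while chloro, an amine or a longer chain such as ethoxy would show how widely this position tolerates change.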